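A few compounds are considered here, and "the series" means these few. Any claim that something is new, unique, unknown or untested is made for them only; others in the source may bear on it.

Measured so far:
Compound 1, `CCCCCCNc1cnc(C(=O)NCc2ccccc2)cn1`, in an ADME assay on MDCK cells (Canis lupus familiaris) for cytotoxicity, read by microscopy, with a stated time of 6 days (on this read-out lower numbers stand for higher toxicity in this test and higher numbers for lower toxicity in this test), gives > 100000 nM, a limit of the assay rather than a number.
Compound 2, `CCCCNc1nccnc1C(=O)NCc1ccccc1`, in this assay gives > 100000 nM, again a limit and not a number.

Compound 2 therefore stands where every value shown stands, at the limit of > 100000 nM in this assay, at which 2 of the 2 values shown sit. Compound 3, `CCCCCNc1nccnc1C(=O)NCc1ccccc1`, differs from compound 2 only by methyl in place of hydrogen on a saturated chain carbon, four bonds along the chain from a nitrogen on an aromatic ring. Within the data shown here, no step between measured compounds exists here. Because compound 2 sits at the limit of > 100000 nM in this assay, at which 2 of the 2 values shown sit, for compound 3 the step of a number no higher from compound 2 to compound 3 (the limit leaves the size open) is expected to be none beyond the usual scatter. Compound 3 is estimated at 100000 nM, between 50000 nM and 200000 nM, and is expected to be reported as a limit again.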

Compound 3, minimum cytotoxic concentration: >= 20000 nM
Compound 3: no number, only a limit; the forecaster's own chance of this, stated with the estimate: 85%; the middle value lies beyond the limit too.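

Compound 2 and compound 3 each carry only a limit in this assay, and no step can be read between them. The compounds shown leave open whether methyl in place of hydrogen on that chain changes the read-out at all.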